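Amide versus sulfonamide on the shared core

The source may hold more compounds than are shown below. What is called first, only, known or untested is meant among the compounds shown, and "the series" means these compounds.

Working notes on the series. Compound 2 `COc1ccc(S(=O)(=O)N2CCc3cccc(NC(=O)c4cccs4)c32)cc1` shows the shared core with a (thiophen-2-yl)carbonyl amide; in a functional assay on KB cells (Homo sapiens) for cytotoxicity (on this read-out higher numbers stand for weaker inhibition and lower numbers for stronger inhibition), compound 2 gives 47 nM. Compound 1 `COc1ccc(S(=O)(=O)N2CCc3cc(Br)cc(NC(=O)c4ccncc4)c32)cc1` differs from it in two places and in this assay gives 91 nM. Compound 3 `COc1ccc(S(=O)(=O)N2CCc3cccc(NS(=O)(=O)c4ccc(F)cc4)c32)cc1` carries a (4-fluorophenyl)sulfonyl on the ring nitrogen instead of the carbonyl group; in this assay compound 3 gives 1200 nM, the highest of the three numbers, beyond the scatter from both compound 1, the nearest, and compound 2, the furthest.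

Compound 4 `COc1ccc(S(=O)(=O)N2CCc3cccc(NC(=O)c4ccccc4)c32)cc1` is not yet measured. Relative to compound 3 the change is benzoyl in place of (4-fluorophenyl)sulfonyl on a nitrogen on an aromatic ring. Among the compounds with values here, the only measured step that bears on it is a 26-fold higher number from compound 2 to compound 3 (1.41 log units; beyond the scatter), which is the same kind of exchange run the other way: carbonyl replaced by sulfonyl. Compound 4 returns to a carbonyl-linked aromatic ring, so a large fall in the number is expected, close to a reversal of that step, a 20-fold lower number from compound 3 to compound 4 (1.30 log units; beyond the scatter). For compound 4 the estimate in this assay is 60 nM, with a range from 25 nM to 200 nM.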

Compound 4, half-maximal inhibitory concentration: 297 nM
The estimate for compound 4 lay 5.0-fold (0.69 log units) below the measured number; measured number outside the range, above it.
By their numbers in this assay, from the lowest: compounds 2 and 1 (each within the scatter of the next); then compound 4; then compound 3.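

With the ring on the carbonyl carbon changed to phenyl, the carbonyl link still gives the lower number in this assay: the exchange for the sulfonyl link shows a 4.0-fold lower number from compound 3 to compound 4 (0.61 log units; beyond the scatter) on this nitrogen. The ring itself also counts, since a 6.3-fold higher number from compound 2 to compound 4 (0.80 log units; beyond the scatter) arises with the link held as a carbonyl. The earlier 26-fold higher number from compound 2 to compound 3 (1.41 log units; beyond the scatter) therefore cannot be read as an effect of the link alone, as that exchange also replaces thiophen-2-yl with 4-fluorophenyl and removes no doubt about which part carries the change.

Still open, going by these compounds, is how a 4-fluorobenzoyl group would compare with compound 3 on this nitrogen, and whether an aliphatic amine chain on the carbonyl carbon would be tolerated. No supporting data are available to explain any of these steps.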